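Swapping fluorine for methyl on the cyclopropyl amide

The compounds below may be only part of what the source reports. "The series", "measured", "known", "first", "only" and "open" are said of these compounds alone.

Compound 1 `O=C(C1CCC1)N1CC2CC(C1)N2`: 240 nM
Compound 2 `O=C([C@H]1C[C@H]1F)N1CC2CC(C1)N2`: 27 nM
Compound 3 `O=C([C@@H]1C[C@H]1F)N1CC2CC(C1)N2`: 43 nM

In an assay on CHO cells for displacement of a labelled ligand from Neuronal acetylcholine receptor; alpha3/alpha6/beta2/beta3 (Homo sapiens), read by scintillation counting (a higher number here means a weaker inhibitor, a lower number a stronger inhibitor), compound 3 gives 43 nM, the second highest of the three numbers, close to compound 2 and well apart from compound 1. Compound 4 `C[C@H]1C[C@H]1C(=O)N1CC2CC(C1)N2` differs from compound 3 by 2-methylcyclopropyl in place of 2-fluorocyclopropyl on a carbonyl carbon. The measured steps only show that replacing cyclobutyl by 2-fluorocyclopropyl lowers the number, an 8.9-fold lower number from compound 1 to compound 2 (0.95 log units; beyond the scatter) and a 5.6-fold lower number from compound 1 to compound 3 (0.75 log units; beyond the scatter), while the two fluorocyclopropyl isomers sit together, a 1.6-fold higher number from compound 2 to compound 3 (0.20 log units; within the scatter). Among the compounds with values here, no measured step exchanges fluorine for methyl, so the direction is uncertain. The estimate for compound 4 is a small step, a 1.4-fold higher number from compound 3 to compound 4 (0.14 log units; within the scatter), likely within the scatter. Compound 4 is therefore expected to give about 60 nM, between 20 nM and 200 nM.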

Compound 4, inhibition constant: 170 nM
Beside the measured number, compound 4's estimate is 2.8-fold (0.45 log units) below it; the measured number falls inside the stated range.
By their numbers in this assay, from the lowest: compounds 2 and 3 (each within the scatter of the next); then compounds 4 and 1 (each within the scatter of the next).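

In this assay, 2-methylcyclopropyl in place of 2-fluorocyclopropyl gives a 4.0-fold higher number from compound 3 to compound 4 (0.60 log units; beyond the scatter) and a 6.3-fold higher number from compound 2 to compound 4 (0.80 log units; beyond the scatter), so at this carbonyl position the three-membered ring alone does not bring the lower numbers. With a 1.4-fold lower number from compound 1 to compound 4 (0.15 log units; within the scatter), 2-methylcyclopropyl and cyclobutyl cannot be told apart here, and among these compounds the lower numbers go only with the fluorine-bearing groups.

As far as these compounds go, whether an unsubstituted cyclopropyl or a 2-chlorocyclopropyl would sit with the fluorine compounds or with the methyl compound remains open. Nothing given here explains the difference between fluorine and methyl.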